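This account rests on a few compounds, and the source may have more. Where it says the series, first, only, none or still open, it means among the compounds named here.

Compound 1, with the structure `COc1ccc(C(=O)/C=C/c2cc3ccccc3[nH]c2=O)cc1`, carries a methyl on an oxygen of its outer aromatic ring. In an ADME assay on M14 cells (Homo sapiens) for cytotoxicity, read by sulforhodamine B assay, with a stated time of 24 h (on this read-out higher numbers stand for lower toxicity in this test and lower numbers for higher toxicity in this test), compound 1 reaches only a limit of the test, > 100000 nM. Compound 2, with the structure `O=C(/C=C/c1cc2ccccc2[nH]c1=O)c1ccc(O)cc1`, differs from it only in a hydrogen in place of the methyl on that oxygen. In this assay compound 2 likewise stops at a limit, > 100000 nM. Going by the values given here, the step that the two limits leave unreadable from compound 1 to compound 2 therefore cannot be read as a number, and the only thing the two values share is the limit of > 100000 nM in this assay, at which 2 of the 2 values shown sit. Compound 2 thus stands at the edge of what this test can report, with no ranking possible against compound 1.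

Compound 3, with the structure `O=C(/C=C/c1cc2ccccc2[nH]c1=O)c1ccc(Cl)cc1`, is the next change: chloro in place of hydroxy on an aromatic carbon. Among the compounds with values here, no measured step gives a readable size for any change on this outer ring, since both known values are limits. What the data show is only that two close relatives of compound 3 showed no toxicity within the range of the test. The expected step is a number no higher from compound 2 to compound 3 (the limit leaves the size open). Compound 3 is estimated at 100000 nM, within a range of 30000 nM to 300000 nM, most likely again reported as a limit.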

Compound 3, concentration lethal to 50% of the cells: > 100000 nM
Compound 3: a limit, no number; the forecaster's own chance of this, stated with the estimate: 70%; the middle value lies on the limit itself.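

Compound 3 also stops at a limit of the test, > 100000 nM. No step linking compound 3 to compound 1 or compound 2 can therefore be read as a number: the limit of > 100000 nM in this assay, at which 3 of the 3 values shown sit.

The compounds shown leave open how large a difference, if any, the methoxy, hydroxy and chloro groups make in this assay.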